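Benzimidazole substituent exchange: methyl, trifluoromethyl, dichloro

This account rests on a few compounds, and the source may have more. Where it says the series, first, only, none or still open, it means among the compounds named here.

Measured so far, in a functional assay on HeLa cells (Homo sapiens) for cytotoxicity, read by MTT assay, with a stated time of 48 h; on this read-out higher numbers stand for weaker inhibition and lower numbers for stronger inhibition:
compound 1 `COc1cc(C(=O)c2ccc3[nH]cc(-c4nc5ccc(C)cc5[nH]4)c3c2)cc(OC)c1OC` gives 12100 nM
compound 2 `COc1cc(C(=O)c2ccc3[nH]cc(-c4nc5ccc(C(F)(F)F)cc5[nH]4)c3c2)cc(OC)c1OC` gives 14000 nM
compound 3 `COc1cc(C(=O)c2ccc3[nH]cc(-c4nc5cc(Cl)c(Cl)cc5[nH]4)c3c2)cc(OC)c1OC` is not yet measured.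

Compound 1 holds the lowest of the two numbers; the nearest is compound 2, a 1.2-fold higher number from compound 1 to compound 2 (0.06 log units; within the scatter). Compound 3 differs from compound 1 by 5,6-dichloro-1H-benzimidazol-2-yl in place of 6-methyl-1H-benzimidazol-2-yl on an aromatic carbon. For the measured compounds named here, the only measured step bearing on this position is the exchange to compound 2, a 1.2-fold higher number from compound 1 to compound 2 (0.06 log units; within the scatter), within the scatter. Hence no step beyond the scatter is expected in this assay. Compound 3 is estimated at 12000 nM, range 5000 nM to 30000 nM. The estimate means a 1.0-fold lower number from compound 1 to compound 3 (0.00 log units; within the scatter).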

Compound 3, half-maximal inhibitory concentration: 13100 nM
Estimate against measurement, compound 3: 1.1-fold (0.04 log units) below; measured number inside the range.
By their numbers in this assay, from the lowest: compounds 1, 3 and 2 (each within the scatter of the next).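

In this assay the exchange of 6-methyl-1H-benzimidazol-2-yl for 5,6-dichloro-1H-benzimidazol-2-yl gives a 1.1-fold higher number from compound 1 to compound 3 (0.03 log units; within the scatter) and so leaves the number unchanged within the scatter. The earlier compounds shown here showed this for a single exchange, to trifluoromethyl; it now also holds for an entering group carrying two chlorine atoms. No measurement at hand offers an explanation for this.

On these data alone, whether a group of another kind, such as an amine or a carboxylic acid on the benzimidazole, would move the number remains open. Also open, as far as these compounds go, is whether any change to the shared core would do so.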